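A few compounds are considered here, and "the series" means these few. Any claim that something is new, unique, unknown or untested is made for them only; others in the source may bear on it.

Working notes on the series. For the measured compounds named here, compound 3 `OC[C@H]1O[C@@H](n2cnc3c(NCc4ccc(Cl)c(Cl)c4)ncnc32)[C@H](O)[C@@H]1O` is the one member with an actual number in a functional assay on MCF cells (Homo sapiens) for antiproliferative activity, with a stated time of 72 h; a higher number here means a weaker inhibitor, a lower number a stronger inhibitor: in this assay compound 3 gives 88800 nM. Compound 1 `OC[C@H]1O[C@@H](n2cnc3c(NCc4ccccc4F)ncnc32)[C@H](O)[C@@H]1O` reaches only a limit in this assay, > 166000 nM. Compound 2 `COc1ccccc1CNc1ncnc2c1ncn2[C@@H]1O[C@H](CO)[C@@H](O)[C@H]1O` likewise gives a limit in this assay, > 166000 nM. Two of the three values thus sit at the limit of > 166000 nM in this assay, at which 2 of the 3 values shown sit, so the step that the two limits leave unreadable from compound 1 to compound 2 cannot be read. The steps ending at compound 3 read an at least 1.8-fold lower number from compound 1 to compound 3 (0.27 log units; that floor lies within the scatter) and an at least 1.8-fold lower number from compound 2 to compound 3 (0.27 log units; that floor lies within the scatter); both are floors, and each floor lies within the scatter, so compound 3 is not shown as stronger than compounds 1 and 2 beyond doubt.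

Compound 4 `Cc1cccc(CNc2ncnc3c2ncn3[C@@H]2O[C@H](CO)[C@@H](O)[C@H]2O)c1O` differs from compound 3 by 2-hydroxy-3-methylphenyl in place of 3,4-dichlorophenyl on a saturated chain carbon bound to a nitrogen on an aromatic ring. Going by the values given here, the only steps that bear on this change are the two floors above, which show the 3,4-dichlorophenyl member with a number where the 2-fluorophenyl and 2-methoxyphenyl members gave limits. Compound 4 leaves the 3,4-dichlorophenyl behind for a phenyl carrying a hydroxy and a methyl, so the expectation is that the number drifts back toward the limit; the step of a 1.7-fold higher number from compound 3 to compound 4 (0.23 log units; within the scatter) is expected to run toward a weaker inhibitor, with a real chance that only a limit is reported. The estimate for compound 4 is 150000 nM, in the range 60000 nM to 350000 nM.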

Compound 4, half-maximal inhibitory concentration: 6900 nM
For compound 4 the middle estimate is 22-fold (1.34 log units) above the measured one, and the stated range ends above it.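

In this assay, the group on the saturated chain carbon bound to a nitrogen on an aromatic ring can now be seen to move the number well beyond the scatter, which the earlier floors could not show (a 13-fold lower number from compound 3 to compound 4 (1.11 log units; beyond the scatter)). The change to 2-hydroxy-3-methylphenyl runs opposite to the earlier hint that the 3,4-dichlorophenyl member stood ahead, so among these four compounds the chlorine-free compound 4 is the strongest inhibitor, with a hydroxy and a methyl on the ring in place of the two chlorines. The other two steps are also large, though both are floors rather than sizes (an at least 24-fold lower number from compound 2 to compound 4 (1.38 log units; beyond the scatter); an at least 24-fold lower number from compound 1 to compound 4 (1.38 log units; beyond the scatter)), and compounds 1 and 2 give only a limit: the limit of > 166000 nM in this assay, at which 2 of the 4 values shown sit.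

The step between compounds 1 and 2 cannot be read, and the hydroxy and methyl of compound 4 enter together, so their shares in the gain stay unseparated. A 2-hydroxyphenyl or a 3-methylphenyl at this place would divide them, and an aminophenyl or a carboxylic acid on the ring would test whether other groups carry the same gain.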